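This account rests on a few compounds, and the source may have more. Where it says the series, first, only, none or still open, it means among the compounds named here.

- compound 1 `CC/C(=C(/c1ccc(/C=C/C(=O)O)cc1)c1ccc2[nH]ncc2c1)c1ccc(C#N)cc1C` - 5 nM
- compound 2 `CC/C(=C(/c1ccc(/C=C/C(=O)O)cc1)c1ccc2[nH]ncc2c1)c1cnccc1C` - 150 nM

In a functional assay on MCF7 cells (Homo sapiens) for cytotoxicity, read by CellTiter-Glo, with a stated time of 5 days (a higher number here means a weaker inhibitor, a lower number a stronger inhibitor), compound 2 has the higher of the two numbers, at 150 nM. Compound 3 `CC/C(=C(/c1ccc(/C=C/C(=O)O)cc1)c1ccc2[nH]ncc2c1)c1ccncc1Cl` carries 3-chloropyridin-4-yl in place of 4-methylpyridin-3-yl at the same place (3-chloropyridin-4-yl in place of 4-methylpyridin-3-yl on a double-bonded chain carbon bound to a double-bonded chain carbon and a saturated chain carbon). For the measured compounds named here, the only measured step, a 30-fold higher number from compound 1 to compound 2 (1.48 log units; beyond the scatter), was large, but it replaced 4-cyano-2-methylphenyl, whereas this change keeps a six-membered aromatic ring with 1 hetero atom. One step is thin evidence, so no step beyond the scatter is expected in this assay. The estimated step is a 1.3-fold lower number from compound 2 to compound 3 (0.10 log units; within the scatter). Compound 3 is expected at about 120 nM, within an estimated range of 35 nM to 400 nM.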

Compound 3, half-maximal inhibitory concentration: 4 nM
Compound 3: the middle estimate sits 30-fold (1.48 log units) above what was measured; the whole stated range lies above it.
By their numbers in this assay, from the lowest: compounds 3 and 1 (each within the scatter of the next); then compound 2.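

In this assay, the step of a 38-fold lower number from compound 2 to compound 3 (1.57 log units; beyond the scatter) shows that this position is highly sensitive even when the six-membered aromatic ring with 1 hetero atom and the heavy-atom count stay the same. The earlier loss therefore does not follow from simply having such a ring in place of 4-cyano-2-methylphenyl: the other step, a 1.3-fold lower number from compound 1 to compound 3 (0.10 log units; within the scatter), stays within the scatter. No measurement shown here explains the large step.

The change from 4-methylpyridin-3-yl to 3-chloropyridin-4-yl alters both the substituent and the ring arrangement. The compounds shown leave open which matters, and a 3-methylpyridin-4-yl group would help separate the two.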